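Trimming a methyl from compound 3: what to expect

This account rests on a few compounds, and the source may have more. Where it says the series, first, only, none or still open, it means among the compounds named here.

The measured compounds, all in a functional assay on A-375 cells (Homo sapiens) for antiproliferative activity, read by MTT assay, with a stated time of 24 h, tested at 0.41 ug/mL; a lower number here means a weaker effect, a higher number a stronger effect of the compound at the concentration tested:
compound 1, `Cc1ccc2nc(C(=O)Nc3c(F)cc(-c4cccc(F)c4)cc3F)c(C)c(O)c2c1`, gives 1.35%
compound 2, `CCc1ccc2nc(C(=O)Nc3c(F)cc(-c4cccc(F)c4)cc3F)c(C)c(O)c2c1`, gives 3.56%
compound 3, `CCOc1ccc2nc(C(=O)Nc3c(F)cc(-c4cccc(F)c4)cc3F)c(C)c(C(=O)O)c2c1`, gives 11.2%

All three numbers lie within the usual scatter of one another, so none of them stands apart. The unmeasured compound 4, `COc1ccc2nc(C(=O)Nc3c(F)cc(-c4cccc(F)c4)cc3F)c(C)c(C(=O)O)c2c1`, comes from compound 3 by the change (hydrogen in place of methyl on a saturated chain carbon bound to an oxygen on an aromatic ring). The same kind of change has already been made once among the measured compounds, from compound 2 to compound 1, as hydrogen in place of methyl on a saturated chain carbon bound to an aromatic carbon; there it gave a number 2.2 percentage points lower from compound 2 to compound 1 (within the scatter). The place is not the same word for word: in that pair the carbon is bound to an aromatic carbon, whereas in compound 3 it is bound to an oxygen on an aromatic ring. How the core of compound 3 differs from the core of compound 2 is not broken down here.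

Because the earlier step of a number 2.2 percentage points lower from compound 2 to compound 1 (within the scatter) stayed within the scatter, only a small step is expected from compound 3 to compound 4, namely a number 2.2 percentage points lower from compound 3 to compound 4 (within the scatter). For compound 4 the estimated value in this assay is 9%, expected to fall between 2% and 18%.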

Compound 4, a percentage reported as inhibition, at one concentration (the size of the read-out at that concentration, not a potency): 3.87%
Beside the measured number, compound 4's estimate is 5.1 percentage points above it; low and high end bracket the measured number.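

In this assay, cutting ethoxy back to methoxy gave a number 7.3 percentage points lower from compound 3 to compound 4 (within the scatter). Set beside the earlier step on the other core, the same kind of change shows no difference that can be told apart: the same change on two cores in this assay, a number 2.2 percentage points lower (within the scatter) from compound 2 to compound 1 and a number 7.3 percentage points lower (within the scatter) from compound 3 to compound 4, 5.1 percentage points apart, within the scatter of two such steps

This shows that, in these two pairs and at this single tested concentration, removing the methyl left the read-out within the scatter on both cores, but it does not show that the change has the same effect on each core, or any effect at all, and the two places are not identical, one carbon being bound to an aromatic carbon and the other to an oxygen on an aromatic ring.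

The compounds shown leave open whether a larger change at this place, such as a longer chain or an amine in place of the ethoxy, would give a step beyond the scatter. They also leave open how the same change would read on a core carrying a nitrile where compound 3 carries its carboxylic acid.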